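Chloro for methyl on the thiourea aryl ring

This account rests on a few compounds, and the source may have more. Where it says the series, first, only, none or still open, it means among the compounds named here.

Two compounds of this series have numbers in a functional assay on L1210 cells (Mus musculus), with a stated time of 48 h; on this read-out lower numbers stand for stronger inhibition and higher numbers for weaker inhibition. Compound 1, `O=C1Nc2ccc(Br)cc2/C1=N/NC(=S)Nc1ccc(Cl)cc1`, gives 88000 nM in this assay. Compound 2, `Cc1ccc(NC(=S)N/N=C2\C(=O)N(Cc3ccc(Cl)cc3)c3ccc(Br)cc32)cc1`, is reported only as a limit of the assay, >= 500000 nM, so its true position is not known beyond that; this is the limit described by the limit of >= 500000 nM in this assay, at which 1 of the 2 values shown sits. Compound 3, `O=C1/C(=N\NC(=S)Nc2ccc(Cl)cc2)c2cc(Br)ccc2N1Cc1ccc(Cl)cc1`, is not yet measured. It differs from compound 2 by chloro in place of methyl on an aromatic carbon. Among the measured compounds shown here, no pair of measured compounds shows this change alone, so the size of the step cannot be read from the series. With compound 2 sitting at a limit, the step from compound 2 to compound 3 is expected to be small, at most within the usual scatter, an at least 1.2-fold lower number from compound 2 to compound 3 (0.09 log units; that floor lies within the scatter). Compound 3 is expected to give about 400000 nM in this assay, within a range from 100000 nM to 1000000 nM, and quite possibly only a limit again.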

Compound 3, half-maximal inhibitory concentration: >= 500000 nM
Compound 3: a limit, no number; the forecaster's own chance of this, stated with the estimate: 60%; middle value at least 1.2-fold (0.09 log units) from the limit.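

In this assay compound 3 is only a limit, >= 500000 nM, and with compound 2 also a limit, the step for chloro in place of methyl, para to a large group, cannot be read. The readable information concerns the ring nitrogen: 4-chlorobenzyl in place of hydrogen on this amide-type nitrogen gives an at least 5.6-fold higher number from compound 1 to compound 3 (0.75 log units; beyond the scatter). No difference between 4-methylphenyl and 4-chlorophenyl can be seen with the 4-chlorobenzyl group present because the values stop at a limit: the limit of >= 500000 nM in this assay, at which 2 of the 3 values shown sit.

Open, as far as these compounds go, is whether methyl and chloro on the aryl ring differ when the amide hydrogen is kept, where only the chloro compound has a number. Also open, from the compounds shown here alone, is whether a methoxy or dimethylamino group at this position, or a shorter group such as ethyl on the ring nitrogen, would give a measurable value.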